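This account rests on a few compounds, and the source may have more. Where it says the series, first, only, none or still open, it means among the compounds named here.

Measured in an ADME assay on HCT-116 cells (Homo sapiens) for cytotoxicity, read by CellTiter-Glo, with a stated time of 72 h; a lower number here means a stronger inhibitor, a higher number a weaker inhibitor:
- Compound 1 `Cc1cc(C)c(S(=O)(=O)N2CCC(N3CCC(c4ccccc4)CC3)CC2)c(C)c1`: > 5000 nM, a limit
- Compound 2 `Cc1cc(C)c(S(=O)(=O)N2CCC(N3CCC(CCO)CC3)CC2)c(C)c1`: > 5000 nM, a limit
- Compound 3 `Cc1cc(C)c(S(=O)(=O)N2CCC(N3CCC(C(C)C)CC3)CC2)c(C)c1`: > 5000 nM, a limit

Compound 3 has no number of its own, only the limit > 5000 nM. It stands with compound 1 and compound 2 at the limit of > 5000 nM in this assay, at which 3 of the 3 values shown sit.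

Compound 4 `Cc1cc(C)c(S(=O)(=O)N2CCC(N3CCC(Cc4ccccc4F)CC3)CC2)c(C)c1` carries 2-fluorobenzyl in place of isopropyl on a saturated ring carbon.

The measured changes at this carbon give no size: a step that the two limits leave unreadable from compound 1 to compound 3, a step that the two limits leave unreadable from compound 1 to compound 2 and a step that the two limits leave unreadable from compound 2 to compound 3. The nearest guide is compound 1, which also has an aromatic ring there and still gives only the limit > 5000 nM. No step beyond the scatter is therefore expected, and a further limit is the likeliest result. The expected change is a step that the limit leaves unreadable from compound 3 to compound 4. For compound 4 the estimate is 7000 nM, expected to fall between 3000 nM and 15000 nM.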

Compound 4, half-maximal inhibitory concentration: > 5000 nM
Compound 4: a limit, no number (the forecaster's own chance of this, stated with the estimate: 85%); the middle value lies beyond the limit too.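

In this assay, among the compounds shown here, compound 4 gives > 5000 nM, a limit and not a number, so no step from compound 1, compound 2 or compound 3 to compound 4 can be read: the limit of > 5000 nM in this assay, at which 4 of the 4 values shown sit.

The compounds shown leave open what value any of them has, and whether any group on this saturated ring carbon changes it.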